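Swapping the Side Chain Once More on a Shared Core

The source may hold more compounds than are shown below. What is called first, only, known or untested is meant among the compounds shown, and "the series" means these compounds.

Compound 1 `CSCC[C@H](NC(=O)CN(c1nc(Cl)nc2[nH]cnc12)C1CC1)C(=O)OCc1ccccc1` and compound 2 `N=C(N)NCCC[C@H](NC(=O)CN(c1nc(Cl)nc2[nH]cnc12)C1CC1)C(=O)OCc1ccccc1` share one core and differ only in a side chain. In a functional assay on the whole organism (Tail, strain ICR) with Mus musculus as the target, in the tail flick test, with a stated time of 30 min, at a dose of 25 umol/kg by the oral route (on this read-out higher numbers stand for a stronger effect at the one dose given and lower numbers for a weaker effect), compound 1 gives 22.2%, and compound 2 gives 23.2%, so the two sit within the scatter of each other; the step of a number 1 percentage points higher from compound 1 to compound 2 (within the scatter) shows that. Compound 3 `O=C(CN(c1nc(Cl)nc2[nH]cnc12)C1CC1)N[C@@H](CC(=O)OCc1ccccc1)C(=O)OCc1ccccc1` changes the side chain again: a group of 10 heavy atoms (8 carbon, 2 oxygen; one six-membered aromatic ring of carbon only) in place of a group of 6 heavy atoms (3 carbon, 3 nitrogen; no ring), on a saturated chain carbon, two bonds along the chain from an amide-type nitrogen and a carbonyl carbon. Within the data shown here, the one comparable step, that from compound 1 to compound 2, was within the scatter, so for compound 3 a step of about a number 1.2 percentage points lower from compound 2 to compound 3 (within the scatter) is expected, none beyond the scatter. Compound 3 is thus estimated at 22%, within 8% to 38%.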

Compound 3, a percentage reported as activity, at one dose (the size of the read-out at that dose, not a potency): 34.7%
Beside the measured number, compound 3's estimate is 12.7 percentage points below it; low and high end bracket the measured number.
By their numbers in this assay, from the lowest: compounds 1 and 2 (each within the scatter of the next); then compound 3.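

Benzyloxycarbonyl on this saturated chain carbon gives the first steps at this position that go beyond the scatter (a number 11.5 percentage points higher from compound 2 to compound 3 (beyond the scatter)) and (a number 12.5 percentage points higher from compound 1 to compound 3 (beyond the scatter)). The side chain here can therefore change the effect at this one dose, which compound 1 and compound 2 alone did not reveal. Nothing available explains this gain.

As far as these compounds go, it remains open whether the gain comes from the aromatic ring or from the ester. A carboxylic acid in place of benzyloxycarbonyl, or a longer chain carrying the same ester, would help separate the two.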